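A few compounds are considered here, and "the series" means these few. Any claim that something is new, unique, unknown or untested is made for them only; others in the source may bear on it.

Three compounds of the series carry numbers in an assay on HEK293 cells for agonist activity at Toll-like receptor 8 (Homo sapiens), read by a luciferase reporter, with a stated time of 6 h; on this read-out lower numbers stand for an effect already at smaller amounts and higher numbers for an effect only at larger amounts of compound. Compound 1 `CCCCNc1nc(N)nc2c1CN(C(C)=O)CC2` gives 0.5 uM in this assay. Compound 2 `CCCCNc1nc(N)nc2c1CCN(C(C)=O)C2` gives 0.4 uM in this assay. Compound 3 `CCCCNc1nc(N)nc2c1CN(Cc1cccc3ccccc13)CC2` gives 0.43 uM in this assay. Compound 1 has the highest of the three numbers, but its gap to compound 3 and its gap to compound 2 both lie within the scatter, so no order among the three can be read from these values. For the measured compounds named here, no step between measured compounds that differ in only one place is available; compound 2 and compound 3 each differ from compound 1 in more than one respect.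

Compound 4 `CCCCNc1nc(N)nc2c1CN(C(=O)c1cscn1)CC2` has not yet been measured in this assay. It differs from compound 1 in a single place: 1,3-thiazol-4-yl in place of methyl on a carbonyl carbon. The values of compound 1 and compound 3 show that another substituent on the same nitrogen leaves the number in the same band, though that comparison is not a single-point step. On this basis a step from compound 1 to compound 4 in this assay that stays within the scatter, with no clear direction, is expected: a 1.4-fold lower number from compound 1 to compound 4 (0.15 log units; within the scatter). For compound 4 a value of 0.35 uM is estimated, within a range of 0.08 uM to 1.5 uM.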

Compound 4, minimum effective concentration: 0.5 uM
Compound 4: the middle estimate sits 1.4-fold (0.15 log units) below what was measured; low and high end bracket the measured number.
By their numbers in this assay, from the lowest: compounds 2, 3, 1 and 4 (each within the scatter of the next).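

Putting 1,3-thiazol-4-yl in place of methyl on a carbonyl carbon, whose other neighbour is the amide-type nitrogen in a ring, gives no change at the digits printed from compound 1 to compound 4 (within the scatter) in this assay. For the compounds shown here, this is the first step that changes a single place, and it shows that at this carbonyl carbon a group of five heavy atoms, with one five-membered aromatic ring and two hydrogen-bond acceptors, can replace the single carbon of methyl without moving the number beyond the scatter. No measurement is available that bears on why the number holds across this change.

The compounds shown leave open whether this tolerance extends to other groups on the same carbonyl carbon, such as a phenyl ring, a longer alkyl chain, a primary amine or a carboxylic acid. They also leave open whether 1,3-thiazol-4-yl in place of methyl gives the same result on the core of compound 2, and whether a change at this carbonyl carbon would still read the same with a chain other than butyl on the shared core.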